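Swapping a Pyridine Attachment Point in a Cytotoxicity Screen

The compounds below may be only part of what the source reports. "The series", "measured", "known", "first", "only" and "open" are said of these compounds alone.

Three compounds built on one shared core were run in an ADME assay on HEK-293T cells (Homo sapiens) for cytotoxicity, read by MTT assay, with a stated time of 24 h; on this read-out lower numbers stand for higher toxicity in this test and higher numbers for lower toxicity in this test. Compound 2 `O=C(c1cccnc1)n1c(-c2cn(-c3ccccc3)nc2-c2ccc(F)cc2)nc2ccccc21` gives 216000 nM. Compound 1 `O=C(c1ccncc1)n1c(-c2cn(-c3ccccc3)nc2-c2ccc(F)cc2)nc2ccccc21` gives 151000 nM; the change between these two is pyridin-4-yl in place of pyridin-3-yl on a carbonyl carbon, and the step is a 1.4-fold lower number from compound 2 to compound 1 (0.16 log units; within the scatter). Compound 3 `Cc1ccc(-c2nn(-c3ccccc3)cc2-c2nc3ccccc3n2C(=O)c2cccnc2)cc1` gives 189000 nM, and its step from compound 2 is a 1.1-fold lower number from compound 2 to compound 3 (0.06 log units; within the scatter). All three numbers lie within the usual scatter of one another, so no order among them can be read.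

Compound 4 `Cc1ccc(-c2nn(-c3ccccc3)cc2-c2nc3ccccc3n2C(=O)c2ccncc2)cc1` has not yet been measured in this assay. It differs from compound 3 by pyridin-4-yl in place of pyridin-3-yl on a carbonyl carbon, the same change that turns compound 2 into compound 1, and the place where it happens is described identically in both pairs. The two cores on which this change is made differ by methyl in place of fluoro on an aromatic carbon. For compound 4 the expected step is a 1.4-fold lower number from compound 3 to compound 4 (0.13 log units; within the scatter), resting on the earlier step of a 1.4-fold lower number from compound 2 to compound 1 (0.16 log units; within the scatter) that stayed within the scatter. The estimate for compound 4 is therefore 140000 nM.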

Compound 4, half-maximal cytotoxic concentration: 154000 nM
Estimate against measurement, compound 4: 1.1-fold (0.04 log units) below; low and high end bracket the measured number.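

Exchanging pyridin-3-yl for pyridin-4-yl on the carbonyl carbon of the methyl-bearing core gives a 1.2-fold lower number from compound 3 to compound 4 (0.09 log units; within the scatter), and this step agrees with the one on the fluoro-bearing core: the same change on two cores in this assay, a 1.4-fold lower number (0.16 log units; within the scatter) from compound 2 to compound 1 and a 1.2-fold lower number (0.09 log units; within the scatter) from compound 3 to compound 4, 1.2-fold (0.07 log units) apart, within the scatter of two such steps. Viewed the other way, methyl in place of fluoro gives a 1.0-fold higher number from compound 1 to compound 4 (0.01 log units; within the scatter) on the pyridin-4-yl compounds, which also agrees with the step on the pyridin-3-yl compounds: the same change on two cores in this assay, a 1.1-fold lower number (0.06 log units; within the scatter) from compound 2 to compound 3 and a 1.0-fold higher number (0.01 log units; within the scatter) from compound 1 to compound 4, 1.2-fold (0.07 log units) apart, within the scatter of two such steps. Thus, in this assay, neither change moves the number beyond the scatter on either core, but this does not show a real shared effect, since steps this small cannot be told apart from repeat-to-repeat variation, and two cores cannot establish a rule for the wider series.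

From the compounds shown here alone, it remains open whether an amine or a carboxylic acid in place of the methyl or fluoro would produce a step beyond the scatter. The same question applies to a plain phenyl in place of the pyridine on the carbonyl carbon.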